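Chloro in Place of Hydrogen on the Benzyl Group

This account rests on a few compounds, and the source may have more. Where it says the series, first, only, none or still open, it means among the compounds named here.

Compound 1 `CC(C)(NC(=O)OCc1ccccc1)c1nc(O)c(O)c(C(=O)NN)n1`: in an ADME assay on C8166 cells (Homo sapiens) for cytotoxicity, read by MTT assay, with a stated time of 3 days (on this read-out higher numbers stand for lower toxicity in this test and lower numbers for higher toxicity in this test), compound 1 gives > 500000 nM, which is a limit of the assay rather than a number.
Compound 2 `CC(C)(NC(=O)OCc1ccccc1)c1nc(O)c(O)c(C(=O)NCc2ccc(C(F)(F)F)cc2)n1`: compound 2 gives 58100 nM.
Compound 3 `CC(C)(NC(=O)OCc1ccccc1)c1nc(O)c(O)c(C(=O)NCc2ccccc2)n1`: compound 3 gives 41400 nM.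

Compound 3 and compound 2 stand together, the two within the usual scatter of each other, as seen in a 1.4-fold lower number from compound 2 to compound 3 (0.15 log units; within the scatter). Compound 1 sits apart at the limit (the limit of > 500000 nM in this assay, at which 1 of the 3 values shown sits), so that an at least 8.6-fold lower number from compound 1 to compound 2 (0.93 log units; beyond the scatter) and an at least 12-fold lower number from compound 1 to compound 3 (1.08 log units; beyond the scatter) are both beyond the scatter.

Compound 4 `CC(C)(NC(=O)OCc1ccccc1)c1nc(O)c(O)c(C(=O)NCc2ccccc2Cl)n1` differs from compound 3 in one place: chloro in place of hydrogen on an aromatic carbon. The measured step that bears most on this is a 1.4-fold lower number from compound 2 to compound 3 (0.15 log units; within the scatter), a swap of one substituent on the same six-membered ring, which stayed within the scatter. The two larger steps concern the replacement of amino by a benzyl-type group and do not speak to a change on the ring itself. The expectation for compound 4 is therefore a step of a 1.0-fold lower number from compound 3 to compound 4 (0.01 log units; within the scatter), within the scatter. Compound 4 is estimated at 40000 nM, with a range from 15000 nM to 110000 nM.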

Compound 4, half-maximal cytotoxic concentration: 53900 nM
The estimate for compound 4 lay 1.3-fold (0.13 log units) below the measured number; the range from low to high includes it.
By their numbers in this assay, from the lowest: compounds 3, 4 and 2 (each within the scatter of the next). At a limit, above all of these: compound 1.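

In this assay, chloro on the aromatic carbon ortho to a large group gives a 1.3-fold higher number from compound 3 to compound 4 (0.11 log units; within the scatter), so this first change at that place leaves compound 4 level with compound 3. The two substituted benzyl groups also cannot be told apart, with a 1.1-fold lower number from compound 2 to compound 4 (0.03 log units; within the scatter), which puts 2-chlorobenzyl level with 4-(trifluoromethyl)benzyl. Only the amino group of compound 1 stands apart, in an at least 9.2-fold lower number from compound 1 to compound 4 (0.96 log units; beyond the scatter), and the value for compound 1 is a limit rather than a number: the limit of > 500000 nM in this assay, at which 1 of the 4 values shown sits.

Still open, going by these compounds, is whether a different group at this place on the ring, such as an amine or a carboxylic acid, would shift the number beyond the scatter. Also open, on these data alone, is how a longer chain in place of the benzyl group would read.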